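A few compounds are considered here, and "the series" means these few. Any claim that something is new, unique, unknown or untested is made for them only; others in the source may bear on it.

Among the compounds with values here, in a functional assay on HeLa cells (Homo sapiens) for inhibition, with a stated time of 72 h (on this read-out higher numbers stand for an effect only at larger amounts of compound and lower numbers for an effect already at smaller amounts), three compounds on the shared core have been examined, and only one gave a number. Compound 1 (`COc1cc(CNC2CCCCC2)ccc1OCc1ccc(Cl)nc1`) gives "nd(insoluble)" (no result reported) and so has no value. Within the data shown here, compound 2 (`COc1cc(CNCCCN(C)C)ccc1OCc1ccc(Cl)nc1`) gives 5000 nM as the single number available. Compound 3 (`COc1cc(CNCc2ccc(C(=O)O)cc2)ccc1OCc1ccc(Cl)nc1`) gives "nd(insoluble)" (no result reported) and therefore has no place on the scale of this read-out. Compound 4 (`COc1cc(CNCc2ccncc2)ccc1OCc1ccc(Cl)nc1`) has not been measured. It differs from compound 3 as follows: pyridin-4-yl in place of 4-carboxyphenyl on a saturated chain carbon bound to an amine nitrogen with pyridin-4-yl in place of 4-carboxyphenyl on a saturated chain carbon bound to an amine nitrogen. Among the measured compounds shown here, no step between measured compounds exists to show what such a change does, and compound 3 offers no number to step from. For the measured compounds named here, no step of a particular size or direction can therefore be expected in this assay from the data. Going by the values given here, the only anchor is compound 2 at 5000 nM and a value near it is expected, with neither direction favoured. For compound 4 the estimated value is 5000 nM with 1500 nM to 20000 nM as the expected range.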

Compound 4, half-maximal effective concentration: 400 nM
Compound 4: the middle estimate sits 13-fold (1.10 log units) above what was measured; the measured number lies below the stated range.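

In this assay, the place on a saturated chain carbon bound to an amine nitrogen now yields its first readable change: pyridin-4-yl in place of 2-(dimethylamino)ethyl brings a 13-fold lower number from compound 2 to compound 4 (1.10 log units; beyond the scatter) and shows that the read-out responds strongly to the group at this place. Compound 1 and compound 3 have no value on this scale, so any step to or from either of them cannot be read. No available evidence bears on the reason for this step.

A phenyl or pyridin-3-yl group at this place would be needed to separate the role of the ring nitrogen from that of the aromatic ring. On these data alone, how a morpholine or a longer chain ending in a dimethylamino group would compare also remains open.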